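A few compounds are considered here, and "the series" means these few. Any claim that something is new, unique, unknown or untested is made for them only; others in the source may bear on it.

Of the compounds shown here, three with a shared core have been measured in a functional assay on HEK293 cells for agonist activity at G-protein coupled receptor 39 (Homo sapiens), read by inositol phosphate accumulation; on this read-out higher numbers stand for an effect only at larger amounts of compound and lower numbers for an effect already at smaller amounts. Compound 1 `CNc1nc(NCc2ccc(NC(C)=O)cc2)cc(-c2ccccn2)n1` gives 5 nM in this assay. Compound 2 `FC(F)(F)Oc1ccc(CNc2nc(NCC3CC3)cc(-c3ccccn3)n2)cc1` gives 600 nM, and compound 3 `Cc1nc(NCc2ccc(Cl)cc2)cc(-c2ccccn2)n1` gives 81 nM. Among these three numbers compound 1 stands lowest, and its distance to each of the other two is beyond the usual scatter, so on the numbers shown it is the most potent of the three.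

Compound 4 `CNc1nc(NCc2ccc(S(C)(=O)=O)cc2)cc(-c2ccccn2)n1` differs from compound 1 in one place: methylsulfonyl in place of acetamido on an aromatic carbon. Within the data shown here, no pair of measured compounds shows this same change, so nothing tells directly how far the number moves. Both groups keep the same count of heavy atoms, but a hydrogen-bond donor is given up and an acceptor is gained. Compound 4 is expected to lose some ground, with a step of a 5.0-fold higher number from compound 1 to compound 4 (0.70 log units; beyond the scatter) that stays modest. The estimate for compound 4 is 25 nM, within a range from 5 nM to 120 nM.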

Compound 4, half-maximal effective concentration: 36 nM
For compound 4 the middle estimate is 1.4-fold (0.16 log units) below the measured one; measured number inside the range.
By their numbers in this assay, from the lowest: compound 1; then compound 4; then compound 3; then compound 2.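

Among these compounds, on the aromatic carbon para to a large group, putting methylsulfonyl in place of acetamido gives a 7.2-fold higher number from compound 1 to compound 4 (0.86 log units; beyond the scatter) in this assay, the first direct reading of a change at this position. The hydrogen-bond donor of acetamido is given up in this change, yet compound 4 still gives 36 nM, so on this pair that donor is not needed for a number of this size, although the step is beyond the usual scatter. Nothing shown gives a reason for this step.

As far as these compounds go, it stays open how a nitrile, an amine or a carboxylic acid on this same carbon would compare with acetamido and methylsulfonyl. From the compounds shown here alone, it also stays open whether this change would give a step of the same size with a different group elsewhere on the shared core.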